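The source may hold more compounds than are shown below. What is called first, only, known or untested is meant among the compounds shown, and "the series" means these compounds.

Measured so far:
Compound 1, `O=C(/C=C/c1ccc2c(c1)B(O)OC2)c1ccc(C(F)(F)F)cc1`: in an ADME assay on L929 cells (Mus musculus) for cytotoxicity, read by resazurin assay, with a stated time of 72 h (on this read-out lower numbers stand for stronger inhibition and higher numbers for weaker inhibition), compound 1 gives > 10 ug/mL, a limit of the assay and not a number.
Compound 2, `OB1OCc2ccc(/C=C/C(O)c3ccccc3)cc21`: in this assay compound 2 gives 2.88 ug/mL.

Compound 1 stands at the limit of > 10 ug/mL in this assay, at which 1 of the 2 values shown sits, so its distance from compound 2 cannot be told. Compound 3, `O=C(/C=C/c1ccc2c(c1)B(O)OC2)c1ccc(-c2ccccc2)cc1`, differs from compound 1 by phenyl in place of trifluoromethyl on an aromatic carbon. No step between measured compounds is shown, so the expected step of an at least 1.2-fold lower number from compound 1 to compound 3 (0.09 log units; that floor lies within the scatter) in this assay is a modest one toward stronger inhibition, not clearly beyond the scatter. Compound 3 is expected to give 8 ug/mL, between 2.5 ug/mL and 30 ug/mL.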

Compound 3, half-maximal inhibitory concentration: > 10 ug/mL
Compound 3 was reported as a limit (the forecaster's own chance of this, stated with the estimate: 45%); middle value at least 1.2-fold (0.09 log units) away from the limit.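

In this assay, no step can be read between compound 1 and compound 3, because both are reported only as limits: the limit of > 10 ug/mL in this assay, at which 2 of the 3 values shown sit. On these data alone, whether phenyl in place of trifluoromethyl changes the inhibition at all, and in which direction, remains open.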